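From Imidazolyl to Triazolyl: A Small Ring Swap

A few compounds are considered here, and "the series" means these few. Any claim that something is new, unique, unknown or untested is made for them only; others in the source may bear on it.

In an ADME assay on Vero cells (Chlorocebus sabaeus) for cytotoxicity, read by MTT assay, with a stated time of 72 h (on this read-out higher numbers stand for weaker inhibition and lower numbers for stronger inhibition), compound 1 `CCOC(=O)c1c(C(F)(F)F)[n+]([O-])c2cc(N3CCNCC3)c(F)cc2[n+]1[O-]` gives 31300 nM and compound 2 `CCOC(=O)c1c(C(F)(F)F)[n+]([O-])c2cc(-n3ccnc3)c(F)cc2[n+]1[O-]` gives 19400 nM on the same read-out. These two numbers lie within the usual scatter of each other, so compound 2 stands level with compound 1 on the data so far. Compound 3 `CCOC(=O)c1c(C(F)(F)F)[n+]([O-])c2cc(-n3cncn3)c(F)cc2[n+]1[O-]` keeps the shared core and differs from compound 2 in one group (1H-1,2,4-triazol-1-yl in place of 1H-imidazol-1-yl on an aromatic carbon), with 1H-1,2,4-triazol-1-yl in place of 1H-imidazol-1-yl on an aromatic carbon, ortho to a fluoro group. Among the measured compounds shown here, only one measured step bears on this swap (a 1.6-fold lower number from compound 1 to compound 2 (0.21 log units; within the scatter)), and it concerns a different exchange on that same carbon. With so little to go on, no step beyond the scatter is expected in this assay for the new swap. The expected step is small (a 1.1-fold higher number from compound 2 to compound 3 (0.03 log units; within the scatter)) and stays inside the scatter. For compound 3 the estimated value is 21000 nM with an expected range from 10000 nM to 45000 nM in repeat measurements.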

Compound 3, half-maximal inhibitory concentration: 35400 nM
Compound 3: the middle estimate sits 1.7-fold (0.23 log units) below what was measured; the measured number falls inside the stated range.
By their numbers in this assay, from the lowest: compounds 2, 1 and 3 (each within the scatter of the next).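

In this assay, a third group on this aromatic carbon of the shared core again moves the reading by no more than the scatter: 1H-1,2,4-triazol-1-yl in place of 1H-imidazol-1-yl gives (a 1.8-fold higher number from compound 2 to compound 3 (0.26 log units; within the scatter)), and 1H-1,2,4-triazol-1-yl in place of piperazin-1-yl gives (a 1.1-fold higher number from compound 1 to compound 3 (0.05 log units; within the scatter)). So adding a third hetero atom to the five-membered aromatic ring leaves the number level with compound 2, and all three compounds now stand within the scatter of one another. Nothing available explains these numbers.

The compounds shown leave open whether this carbon would respond to a group of another kind, such as a carboxylic acid, a morpholine ring or a longer chain ending in an amine. They also leave open whether the same ring swap would read alike without the fluoro group.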